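Replacing the Chlorinated Ring Arm with Methyl

The source may report more compounds than this note shows. Statements on the series, on what has been measured and on what is new or still open speak of the compounds shown alone.

compound 1 `Clc1ccccc1-c1cc(-c2cnn(C3CCNCC3)c2)on1` — 120 nM
compound 2 `c1ccc(-c2cc(-c3cnn(C4CCNCC4)c3)on2)cc1` — 100000 nM
compound 3 `Fc1ccc(Cl)c(-c2cc(-c3cnn(C4CCNCC4)c3)on2)c1` — 270 nM

In an assay on isolated protein for positive allosteric modulation of Neuronal acetylcholine receptor; alpha4/beta2 (Homo sapiens) (a higher number here means that more compound is needed for the effect, a lower number that less compound is needed), compound 1 gives the lowest of the three numbers, with the nearest step being a 2.3-fold higher number from compound 1 to compound 3 (0.35 log units; beyond the scatter) and the furthest an 830-fold higher number from compound 1 to compound 2 (2.92 log units; beyond the scatter). Compound 4 `Cc1cc(-c2cnn(C3CCNCC3)c2)on1` differs from compound 1 by methyl in place of 2-chlorophenyl on an aromatic carbon. The step that bears most on this is the loss of chloro alone, an 830-fold higher number from compound 1 to compound 2 (2.92 log units; beyond the scatter), a large rise; the phenyl change a 370-fold lower number from compound 2 to compound 3 (2.57 log units; beyond the scatter) shows how much the substituted ring carries in this assay. Removing the whole 2-chlorophenyl is therefore expected to give a large rise in this assay, a 420-fold higher number from compound 1 to compound 4 (2.62 log units; beyond the scatter), possibly reaching a limit. Compound 4 is estimated at 50000 nM, between 5000 nM and 200000 nM.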

Compound 4, half-maximal effective concentration: 1300 nM
The estimate for compound 4 lay 38-fold (1.59 log units) above the measured number, outside the stated range (below it).
By their numbers in this assay, from the lowest: compound 1; then compound 3; then compound 4; then compound 2.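

In this assay, a ring at this position is not required: methyl in place of phenyl gives a 77-fold lower number from compound 2 to compound 4 (1.89 log units; beyond the scatter), so the unsubstituted phenyl is worse than the much smaller group. The chlorinated rings still outdo methyl, with an 11-fold higher number from compound 1 to compound 4 (1.03 log units; beyond the scatter) and a 4.8-fold higher number from compound 3 to compound 4 (0.68 log units; beyond the scatter), so phenyl raises the number relative to methyl while these rings lower it. Nothing shown gives a reason for this reversal. On these data alone, it remains open whether an ethyl or a longer chain here would follow methyl, and whether a 2-methoxyphenyl would match the chlorinated rings.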